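Swapping the aryl group on the ring amide nitrogen

The source may hold more compounds than are shown below. What is called first, only, known or untested is meant among the compounds shown, and "the series" means these compounds.

Of the compounds shown here, two have been measured in an ADME assay on microsomes from liver (Mus musculus) for metabolic stability, read by LC-MS, using NADPH, with a stated time of 10 min, tested at 0.1 uM; on this read-out higher numbers stand for fast clearance and lower numbers for slow clearance. Compound 1, `CC1SC(c2cccc(C(=O)NCCCCc3ccccc3)c2)N(c2ccc(C3CC3)cc2)C1=O`, carries a phenyl group on the amide-type nitrogen in the ring and gives 3210 mL.min-1.g-1 in this assay. Compound 2, `COc1ccc(F)cc1N1C(=O)CSC1c1cccc(C(=O)NCCCCn2cccn2)c1`, gives 1310 mL.min-1.g-1 in this assay. Compound 2 therefore holds the lowest of the two numbers, and the gap to compound 1 lies beyond the usual scatter, so the two compounds are genuinely told apart by this assay.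

The next compound, compound 3, `O=C(NCCCCn1cccn1)c1cccc(C2SCC(=O)N2c2ccccn2)c1`, has not yet been measured. Its structure differs from compound 2 in one place: pyridin-2-yl in place of 5-fluoro-2-methoxyphenyl on an amide-type nitrogen in a ring.

Going by the values given here, no pair of measured compounds shows this same change, so no measured step can guide the size or direction of the shift. Because compound 2 gives 1310 mL.min-1.g-1, the expectation for compound 3 rests on that single anchor, with a wide range to allow for either direction. The step from compound 2 to compound 3 is expected to be a 1.3-fold lower number from compound 2 to compound 3 (0.12 log units; within the scatter). Compound 3 is estimated to give 1000 mL.min-1.g-1 in this assay, in a range from 350 mL.min-1.g-1 to 2800 mL.min-1.g-1.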

Compound 3, intrinsic clearance in microsomes: 304 mL.min-1.g-1
Compound 3: middle estimate off by 3.3-fold (0.52 log units), on the high side; the measured number lies below the stated range.
By their numbers in this assay, from the lowest: compound 3; then compound 2; then compound 1.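

Placing pyridin-2-yl instead of 5-fluoro-2-methoxyphenyl on the amide-type nitrogen in the ring gives, in this assay, a 4.3-fold lower number from compound 2 to compound 3 (0.63 log units; beyond the scatter). This step lies beyond the usual scatter, so the group at this position can clearly shift the read-out, even with the rest of the structure unchanged. However, the step bundles several changes at once, as the methoxy and the fluorine both leave and a ring nitrogen enters, and nothing available explains why the number moves or shows which of these changes matters.

The compounds shown leave open which part of the swap carries the step, and a plain phenyl, a 2-methoxyphenyl or a 3-fluorophenyl group at this same place would help to separate the loss of each group from the arrival of the ring nitrogen. Also open, as far as these compounds go, is how much the placement of that nitrogen counts, which a pyridin-3-yl or pyridin-4-yl group would address, and whether the step would hold with a different chain on the other amide.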